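A few compounds are considered here, and "the series" means these few. Any claim that something is new, unique, unknown or untested is made for them only; others in the source may bear on it.

In a functional assay on NCI-H1299 cells (Homo sapiens) for antiproliferative activity, read by fluorescence and resazurin assay, with a stated time of 48 h (on this read-out lower numbers stand for stronger inhibition and higher numbers for weaker inhibition), compound 1 `COc1ccc(Cn2cc(-c3ccc(O)cc3)c(-c3ccc(O)cc3)c2)c(OC)c1` gives 31600 nM. Compound 2 `COc1ccc(Cn2cc(-c3ccc(O)cc3)c(-c3ccc(O)cc3)c2)c(OC)c1OC` carries methoxy in place of hydrogen on an aromatic carbon, and in this assay compound 2 gives 25100 nM, a change of a 1.3-fold lower number from compound 1 to compound 2 (0.10 log units; within the scatter). Compound 3 `COc1ccc(Cn2cc(-c3ccc(O)c(O)c3)c(-c3ccc(O)c(O)c3)c2)cc1` gives 8300 nM in this assay; the difference between the cores of compound 1 and compound 3 is not broken down here. Compound 4 `COc1ccc(Cn2cc(-c3ccc(O)c(O)c3)c(-c3ccc(O)c(O)c3)c2)cc1OC` differs from compound 3 by methoxy in place of hydrogen on an aromatic carbon. This is the same kind of change as that from compound 1 to compound 2, though the surroundings differ: in compound 2 the entering group sits ortho to two methoxy groups, in compound 4 ortho to a methoxy group. Since the earlier step of a 1.3-fold lower number from compound 1 to compound 2 (0.10 log units; within the scatter) stayed within the scatter, a similarly small step is expected here. The expected step is a 1.2-fold lower number from compound 3 to compound 4 (0.07 log units; within the scatter). Compound 4 is thus expected to give about 7000 nM, between 3500 nM and 15000 nM.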

Compound 4, half-maximal inhibitory concentration: 10500 nM
The estimate for compound 4 lay 1.5-fold (0.18 log units) below the measured number; the measured number falls inside the stated range.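

In this assay, methoxy in place of hydrogen on an aromatic carbon gave a 1.3-fold higher number from compound 3 to compound 4 (0.10 log units; within the scatter), a step too small to read as a change in either direction. Set beside the earlier step on the other core, it does not differ from it: the same change on two cores in this assay, a 1.3-fold lower number (0.10 log units; within the scatter) from compound 1 to compound 2 and a 1.3-fold higher number (0.10 log units; within the scatter) from compound 3 to compound 4, 1.6-fold (0.20 log units) apart, within the scatter of two such steps. On these two cores, then, the change left the number within the scatter, but two pairs do not show that this would hold on other cores or for other placements of the group.

The compounds shown leave open whether another group at this place, such as an amine, a carboxylic acid or a longer chain, would shift the number beyond the scatter. No pair shown isolates what the hydroxy groups contribute.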